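The compounds below may be only part of what the source reports. "The series", "measured", "known", "first", "only" and "open" are said of these compounds alone.

Measured so far in a physicochemical assay for lipophilicity; on this read-out lower numbers stand for lower lipophilicity and higher numbers for higher lipophilicity:
compound 1 `CNC(=O)c1cc(C(=O)N[C@H]2CC[C@H](O)CC2)n([C@@H](C)c2ccc(Cl)cc2)n1` gives 3.7
compound 2 `CNC(=O)c1cc(C(=O)N[C@H]2CC[C@H](O)CC2)c([C@@H](C)c2ccccc2Cl)o1` gives 3.1
compound 3 `CNC(=O)c1cc(C(=O)N[C@H]2CC[C@H](O)CC2)n([C@@H](C)c2ccccc2Cl)n1` gives 3.9

Compound 4 `CNC(=O)c1cc(C(=O)N[C@H]2CC[C@H](O)CC2)c([C@@H](C)c2ccc(Cl)cc2)o1` is not yet measured in this assay. Between compound 3 and compound 1 the change is 4-chlorophenyl in place of 2-chlorophenyl on a saturated chain carbon bound to an aromatic nitrogen and a saturated chain carbon, and it made a number 0.20 log units lower from compound 3 to compound 1 (within the scatter). Compound 2 and compound 3 carry different cores; the difference between the two cores is not broken down here, and in this assay compound 3 gives 3.9 while compound 2 gives 3.1, a gap beyond the scatter. The change from compound 2 to compound 4 is 4-chlorophenyl in place of 2-chlorophenyl on a saturated chain carbon bound to an aromatic carbon and a saturated chain carbon; here the place is bound to an aromatic carbon rather than an aromatic nitrogen, so it is the same kind of change, not the same. The step is expected to be a number 0.20 log units lower from compound 2 to compound 4 (within the scatter), small because a number 0.20 log units lower from compound 3 to compound 1 (within the scatter) stayed within the scatter. Compound 4 is therefore estimated at 2.9, likely between 2.5 and 3.3.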

Compound 4, distribution coefficient: 3.5
Compound 4: the middle estimate sits 0.60 log units below what was measured; the whole stated range lies below it.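

In this assay, 4-chlorophenyl in place of 2-chlorophenyl gives a number 0.40 log units higher from compound 2 to compound 4 (beyond the scatter), whereas the same kind of swap on the other core gave a number 0.20 log units lower from compound 3 to compound 1 (within the scatter). For these two pairs, then, the step read on one core did not carry over unchanged to the other, although one pair per core cannot establish a general rule for the series. Nothing shown here explains why the two cores differ in this respect.

The compounds shown leave open how either core would respond if an amine or a carboxylic acid took the place of the chlorine. They also leave open which of the two steps, if either, a third core would follow.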